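Ethyl to tert-butyl on an aromatic carbon

The source may report more compounds than this note shows. Statements on the series, on what has been measured and on what is new or still open speak of the compounds shown alone.

In an ADME assay on L02 cells (Homo sapiens) for inhibition, read by CCK-8 assay, with a stated time of 48 h (on this read-out higher numbers stand for weaker inhibition of growth and lower numbers for stronger inhibition of growth), compound 3 (`CCc1ccc(Nc2nc(Nc3ccc(N4CCN(C)CC4)cn3)ncc2Cl)cc1`) reads 12100 nM and stands within the scatter of compound 2 (`Cc1cccc(Nc2nc(Nc3ccc(N4CCN(C)CC4)cn3)ncc2Cl)c1`) at 6080 nM and lower than compound 1 (`COc1ccccc1CNc1nc(Nc2ccc(N3CCN(C)CC3)cn2)ncc1Cl`) at 25500 nM on this read-out. Compound 4 (`CN1CCN(c2ccc(Nc3ncc(Cl)c(Nc4ccc(C(C)(C)C)cc4)n3)nc2)CC1`) carries tert-butyl in place of ethyl on an aromatic carbon. The closest measured change is a 2.0-fold higher number from compound 2 to compound 3 (0.30 log units; within the scatter) and does not leave the scatter. Only the wider replacements gave modest steps (a 4.2-fold lower number from compound 1 to compound 2 (0.62 log units; beyond the scatter) and a 2.1-fold lower number from compound 1 to compound 3 (0.32 log units; beyond the scatter)). No step beyond the scatter is therefore expected, the estimate being a 1.1-fold lower number from compound 3 to compound 4 (0.04 log units; within the scatter) in either direction of little weight. In this assay the estimated value for compound 4 is 11000 nM (expected range 5000 nM to 25000 nM).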

Compound 4, concentration for 50% growth inhibition: 6070 nM
Beside the measured number, compound 4's estimate is 1.8-fold (0.26 log units) above it, and the stated range covers the measured number.
By their numbers in this assay, from the lowest: compounds 4, 2 and 3 (each within the scatter of the next); then compound 1.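

In this assay, the move from ethyl to tert-butyl on this aromatic carbon stays within the scatter (a 2.0-fold lower number from compound 3 to compound 4 (0.30 log units; within the scatter)), so the two added carbons leave the reading unmoved. Compound 4 also matches the 3-methylphenyl compound (a 1.0-fold lower number from compound 2 to compound 4 (0.00 log units; within the scatter)), and only the replacement of 2-methoxybenzyl leaves the scatter (a 4.2-fold lower number from compound 1 to compound 4 (0.62 log units; beyond the scatter)). No measurement shown here bears on why these readings fall as they do. As far as these compounds go, whether an amine, a carboxylic acid or a longer chain on this same carbon would shift the reading remains open.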